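From compound 3 to compound 4: bromo gives way to fluoro

The source may report more compounds than this note shows. Statements on the series, on what has been measured and on what is new or still open speak of the compounds shown alone.

In a functional assay on M21 cells (Homo sapiens) for antiproliferative activity, read by sulforhodamine B assay, with a stated time of 48 h (a higher number here means a weaker inhibitor, a lower number a stronger inhibitor), compound 1 `CCCCN1CCN(c2ccc(S(=O)(=O)Oc3cccc(OC)c3)cc2)C1=O` gives 30000 nM and compound 3 `CCCCN1CCN(c2ccc(S(=O)(=O)Oc3cccc(Br)c3)cc2)C1=O` gives 35000 nM. These two values lie within the scatter of each other, as a 1.2-fold higher number from compound 1 to compound 3 (0.07 log units; within the scatter) shows, for bromo in place of methoxy on an aromatic carbon. Compound 2 `CCCCN1CCN(c2ccc(S(=O)(=O)Oc3cccc(F)c3)cc2)C1=O` gives > 100000 nM, which is a limit of the assay and not a number. Compound 3 therefore stands level with compound 1, and the only other result is a limit.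

Compound 4 `CCCCN1CCN(c2ccc(S(=O)(=O)Oc3ccc(F)c(F)c3)cc2)C1=O` carries 3,4-difluorophenyl in place of 3-bromophenyl on an oxygen. Going by the values given here, two measured steps bear most directly on this change. Fluoro in place of methoxy gave an at least 3.3-fold higher number from compound 1 to compound 2 (0.52 log units; beyond the scatter), and bromo in place of fluoro gave an at least 2.8-fold lower number from compound 2 to compound 3 (0.45 log units; beyond the scatter). Among the compounds with values here, both lie beyond the scatter and both involve compound 2, the only measured compound with fluoro. Within the data shown here, no measured compound carries two fluoro groups, so the transfer is uncertain. Even so, a modest move towards a weaker result is expected, and the expected change is a 2.0-fold higher number from compound 3 to compound 4 (0.30 log units; within the scatter). The assay may also report only a limit. For compound 4 the estimated value is 70000 nM, with an expected range from 25000 nM to 200000 nM.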

Compound 4, half-maximal inhibitory concentration: > 100000 nM
Compound 4: no number, only a limit; the forecaster's own chance of this, stated with the estimate: 45%; at least 1.4-fold (0.15 log units) between middle value and limit.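

Replacing 3-bromophenyl with 3,4-difluorophenyl on the oxygen attached to the sulfonyl sulfur gives, in this assay, an at least 2.8-fold higher number from compound 3 to compound 4 (0.45 log units; beyond the scatter), and replacing the methoxy-bearing group of compound 1 gives an at least 3.3-fold higher number from compound 1 to compound 4 (0.52 log units; beyond the scatter); both steps are bounded by a limit of the assay and not fixed by a number. Among the four compounds shown, compound 2 and compound 4, the two with fluoro on this aromatic ring, both end at the limit, whereas compound 1 and compound 3 give numbers, and no compound shown goes against this. The step from compound 2 to compound 4, fluoro in place of hydrogen on an aromatic carbon, cannot be read because both compounds sit at the same limit: the limit of > 100000 nM in this assay, at which 2 of the 4 values shown sit.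

As far as these compounds go, how far compound 2 and compound 4 lie past the limit stays open, and so does whether the second fluoro changes the result at all. From the compounds shown here alone, it also remains open whether an amine or a carboxylic acid on this aromatic ring would give a lower number than those of compound 1 and compound 3.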